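The compounds below may be only part of what the source reports. "The series", "measured", "known", "first", "only" and "open" are said of these compounds alone.

Compound 1 `C=C1CC[C@@H]2[C@](C)(CO)[C@H](OC(C)=O)CC[C@@]2(C)[C@@H]1C/C=C1/C(=O)OC[C@H]1O` needs the most material of the three measured compounds: in a functional assay on Col2 cells (Homo sapiens) for cytotoxicity, read by sulforhodamine B assay (a higher number here means that more compound is needed for the effect, a lower number that less compound is needed), compound 1 gives 27.2 uM. Compound 3 `C=C1CC[C@@H]2[C@](C)(COC(C)=O)[C@H](O)CC[C@@]2(C)[C@@H]1C/C=C1/C(=O)OC[C@H]1O` gives 12.9 uM in this assay, and compound 2 `C=C1CC[C@@H]2[C@](C)(CO[Si](C(C)C)(C(C)C)C(C)C)[C@H](O)CC[C@@]2(C)[C@@H]1C/C=C1/C(=O)OC[C@H]1O` gives 2.73 uM. The unmeasured compound 4 `C=C1CC[C@@H]2[C@](C)(CO[Si](C)(C)C(C)(C)C)[C@H](OC(C)=O)CC[C@@]2(C)[C@@H]1C/C=C1/C(=O)OC[C@H]1O` differs from compound 1 by a group of 7 heavy atoms (6 carbon, 1 silicon; no ring) in place of a hydrogen atom, on an oxygen on a saturated carbon. Among the compounds with values here, no measured step matches this change directly. The closest guide is a 4.7-fold higher number from compound 2 to compound 3 (0.67 log units; beyond the scatter), where the silicon-containing group on that same oxygen gave way to an acetyl group, and compound 2, which carries the silicon-containing group, lies furthest below compound 1 in this assay. The analyst therefore expects a downward step beyond the scatter, a 4.5-fold lower number from compound 1 to compound 4 (0.66 log units; beyond the scatter). Compound 4 is estimated at 6 uM, within 2 uM to 18 uM.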

Compound 4, concentration for half-maximal effect: 11.3 uM
Compound 4: middle estimate off by 1.9-fold (0.27 log units), on the low side, and the stated range covers the measured number.
By their numbers in this assay, from the lowest: compound 2; then compounds 4 and 3 (each within the scatter of the next); then compound 1.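

In this assay, the step of a 2.4-fold lower number from compound 1 to compound 4 (0.38 log units; beyond the scatter) is the first shown in which a free hydroxyl hydrogen, rather than another group, gives way to a silicon-bearing group on this oxygen. The earlier step only exchanged one group on that oxygen for another, so this one shows that filling the position with this group of 7 heavy atoms goes with a lower number. Nothing available explains this step. The compounds shown leave open whether a methyl or benzyl group on this oxygen would shift the number in the same direction. They also leave open whether the step depends on the silicon itself.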